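Swapping the pyridyl for a chlorophenyl on the ring nitrogen

This account rests on a few compounds, and the source may have more. Where it says the series, first, only, none or still open, it means among the compounds named here.

Three compounds share one core and differ only in the aryl group carried on the amine nitrogen of the six-membered ring with two nitrogens. Compound 1 `Nc1scc(CN2CCN(c3ccncc3)CC2)c1C(=O)c1ccc(Cl)cc1` is the pyridin-4-yl member; in a functional assay on CHO cells with adenosine receptor A1 (Homo sapiens) as the target, read by cAMP accumulation and immunoassay, with a stated time of 6 min, tested at 10 uM (a lower number here means a stronger effect, a higher number a weaker effect of the compound at the concentration tested), compound 1 gives -15%, the highest of the three numbers. Compound 2 `Nc1scc(CN2CCN(c3ccc(C(F)(F)F)cc3)CC2)c1C(=O)c1cccc(C(F)(F)F)c1` gives -47%, and compound 3 `Nc1scc(CN2CCN(c3cccc(F)c3)CC2)c1C(=O)c1cccc(C(F)(F)F)c1` gives -62%. For the measured compounds named here, the only single-point step among them, a number 15 percentage points lower from compound 2 to compound 3 (beyond the scatter), shows that exchanging one aryl group for another at this nitrogen can shift the read-out by a moderate amount.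

Compound 4 `Nc1scc(CN2CCN(c3ccccc3Cl)CC2)c1C(=O)c1ccc(Cl)cc1` is the untested analogue of compound 1, altered by 2-chlorophenyl in place of pyridin-4-yl on an amine nitrogen in a ring. Since both phenyl-type compounds, compound 2 and compound 3, sit well below compound 1, a carbon-only aryl in this position is expected to push the number lower, though the size is uncertain. The estimated step is a number 15 percentage points lower from compound 1 to compound 4 (beyond the scatter), and compound 4 is therefore expected to give about -30%, within a range from -55% to -5%.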

Compound 4, a percentage reported as activity, at one concentration (the size of the read-out at that concentration, not a potency): -18%
Estimate against measurement, compound 4: 12 percentage points below, within the range that was stated.
By their numbers in this assay, from the lowest: compound 3; then compound 2; then compounds 4 and 1 (each within the scatter of the next).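

In this assay the exchange of pyridin-4-yl for 2-chlorophenyl gives a number 3 percentage points lower from compound 1 to compound 4 (within the scatter) and so shows that, with this core, a carbon-only aryl on this ring nitrogen does not by itself lower the number. Compound 2 and compound 3 also differ from compound 1 in a second place, the other aryl group on the core, so their lower numbers cannot be credited to the aryl group on this nitrogen alone. No measurement here explains why the read-out stays within the scatter across this exchange.

Still open, on these data alone, is how 3-fluorophenyl on this nitrogen would behave with the core of compound 1, a comparison that would separate the effects of the two places. Also open, as far as these compounds go, is what a non-aromatic group, such as an acetyl or a simple alkyl chain, would do on this nitrogen.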